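Methylthiazole in place of fluorobenzyl: half-life notes

The compounds below may be only part of what the source reports. "The series", "measured", "known", "first", "only" and "open" are said of these compounds alone.

Measured so far in an ADME assay on microsomes from liver (Rattus norvegicus) for metabolic stability, read by LC-MS, tested at 0.5 uM; on this read-out higher numbers stand for a longer-lived compound and lower numbers for a shorter-lived compound:
- compound 1 `Cc1nc(C)c([C@H](OC(C)(C)C)C(=O)O)c(N2CCC(C)(C)CC2)c1-c1ccc(OCCc2ccc(F)cc2F)cc1`; compound 1 gives > 2 h, which is a limit of the assay.
- compound 2 `Cc1nc(C)c([C@H](OC(C)(C)C)C(=O)O)c(N2CCC(C)(C)CC2)c1-c1ccc(OCCc2ccc(F)c(F)c2)cc1`; compound 2 gives 0.85 h.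
- compound 3 `Cc1nc(C)c([C@H](OC(C)(C)C)C(=O)O)c(N2CCC(C)(C)CC2)c1-c1ccc(OCCCc2ccc(F)cc2)cc1`; compound 3 gives > 2 h, which is a limit of the assay.

Compound 3 therefore stands only at a limit in this assay. Because of the limit of > 2 h in this assay, at which 2 of the 3 values shown sit, its place relative to compound 1 cannot be read, as a step that the two limits leave unreadable from compound 1 to compound 3 shows; against compound 2 the step of an at least 2.3-fold higher number from compound 2 to compound 3 (0.37 log units; beyond the scatter) is beyond the scatter.

Compound 4 `Cc1nc(CCOc2ccc(-c3c(C)nc(C)c([C@H](OC(C)(C)C)C(=O)O)c3N3CCC(C)(C)CC3)cc2)cs1` carries the change (2-methyl-1,3-thiazol-4-yl in place of 4-fluorobenzyl on a saturated chain carbon, two bonds along the chain from an oxygen on an aromatic ring). Among the compounds with values here, none of the measured steps covers a ring of this kind: an at least 2.3-fold lower number from compound 1 to compound 2 (0.37 log units; beyond the scatter) and the two steps toward compound 3 exchange 2,4-difluorophenyl for 3,4-difluorophenyl or for 4-fluorobenzyl, all carbon-only six-membered rings. Within the data shown here, the size of the step to compound 4 therefore rests on no measured precedent, and a step of either sign within roughly the scatter is expected, written as an at least 1.2-fold lower number from compound 3 to compound 4 (0.09 log units; that floor lies within the scatter). Compound 4 is estimated at 1.6 h, with a range from 0.6 h to 2.5 h, and a fair chance that this assay again returns only a limit.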

Compound 4, half-life: 1.75 h
Beside the measured number, compound 4's estimate is 1.1-fold (0.04 log units) below it; the measured number falls inside the stated range.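

Compound 4 gives a measured half-life rather than a limit in this assay, so this position, on a saturated chain carbon, two bonds along the chain from an oxygen on an aromatic ring, can carry a five-membered aromatic ring with 2 hetero atoms and still give a readable number. Against the 3,4-difluorophenyl group, the change to 2-methyl-1,3-thiazol-4-yl gives a 2.1-fold higher number from compound 2 to compound 4 (0.31 log units; beyond the scatter). Against the two compounds at the limit, only floors can be stated: an at least 1.1-fold lower number from compound 3 to compound 4 (0.05 log units; that floor lies within the scatter) and an at least 1.1-fold lower number from compound 1 to compound 4 (0.05 log units; that floor lies within the scatter).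

The true size of those two steps remains unread: the limit of > 2 h in this assay, at which 2 of the 4 values shown sit.

Going by these compounds, also open in this assay is how a pyridine ring, or a 2-methyl-1,3-thiazol-4-yl group on a longer chain, would compare at this position.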